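Replacing the 2-cyanophenyl group of compound 2

The source may hold more compounds than are shown below. What is called first, only, known or untested is meant among the compounds shown, and "the series" means these compounds.

Measured in a functional assay on MCF7 cells (Homo sapiens) for cytotoxicity, read by CellTiter-Glo, with a stated time of 5 days; on this read-out lower numbers stand for stronger inhibition and higher numbers for weaker inhibition:
compound 1 `CC/C(=C(\c1ccc2[nH]ncc2c1)c1ccc(/C=C/C(=O)O)cc1OC)c1ccccc1`: 12 nM
compound 2 `CC/C(=C(/c1ccc(/C=C/C(=O)O)cc1)c1ccc2[nH]ncc2c1)c1ccccc1C#N`: 12 nM

Compound 2 stands level with compound 1, the two values lying within the usual scatter of repeated measurements. Compound 3 `CC/C(=C(/c1ccc(/C=C/C(=O)O)cc1)c1ccc2[nH]ncc2c1)c1cccnc1C` carries 2-methylpyridin-3-yl in place of 2-cyanophenyl on a double-bonded chain carbon bound to a double-bonded chain carbon and a saturated chain carbon. Within the data shown here, no measured pair here shows what such a swap does, so the expected range stays wide. In this assay a modest weakening is expected, an estimated 2.1-fold higher number from compound 2 to compound 3 (0.32 log units; beyond the scatter). For compound 3 the estimate is 25 nM, with a range from 7 nM to 90 nM.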

Compound 3, half-maximal inhibitory concentration: 200 nM
Compound 3: middle estimate off by 8.0-fold (0.90 log units), on the low side; measured number above the stated range.
By their numbers in this assay, from the lowest: compounds 1 and 2 (each within the scatter of the next); then compound 3.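

In this assay, this position proves sensitive: 2-methylpyridin-3-yl in place of 2-cyanophenyl gives a 17-fold higher number from compound 2 to compound 3 (1.22 log units; beyond the scatter), a large weakening, even though both groups are six-membered aromatic rings with the same counts of hydrogen-bond donors and acceptors. Those shared counts therefore do not make the two groups interchangeable on this double-bonded chain carbon. The information available offers no reason for the step.

Going by these compounds, it remains open whether the ring nitrogen or the exchange of nitrile for methyl matters more. A 2-methylphenyl group here would separate the two.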